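The source may hold more compounds than are shown below. What is called first, only, known or untested is meant among the compounds shown, and "the series" means these compounds.

Compound 1 `Cc1ccc(C(=O)c2cc(F)c(OCC(=O)NNC(=O)c3ccc(=O)oc3)c(Cl)c2)cc1`: 24200 nM
Compound 2 `Cc1ccc(C(=O)c2cc(F)c(OCC(=O)NNC(=O)c3cn(C)cn3)c(Cl)c2)cc1`: 9400 nM

Both compounds were tested in a functional assay on MCF7 cells (Homo sapiens) for cytotoxicity, read by LDH release, with a stated time of 48 h; on this read-out lower numbers stand for stronger inhibition and higher numbers for weaker inhibition. On these numbers compound 1, at 24200 nM, stands as the higher of the two, so it is the weaker of this pair. Compound 3 `O=C(COc1c(F)cc(C(=O)c2ccc(Cl)cc2)cc1Cl)NNC(=O)c1ccc(=O)oc1` has not yet been measured in this assay. It keeps the core of compound 1 and differs from it in one place: chloro in place of methyl on an aromatic carbon. This is chloro in place of methyl on an aromatic carbon, with 4-methylphenyl becoming 4-chlorophenyl.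

Among the measured compounds shown here, only one measured step is available, a 2.6-fold lower number from compound 1 to compound 2 (0.41 log units; beyond the scatter). It is modest and concerns a group on a carbonyl carbon, not the methyl, so it bears on this change only indirectly, as a guide to how far a single change has moved the numbers here. For the measured compounds named here, no measured step shows what replacing this methyl does. No step beyond the scatter is therefore expected, and the data favour no direction. The expected change is a 1.1-fold lower number from compound 1 to compound 3 (0.04 log units; within the scatter). For compound 3 the estimated value is 22000 nM, with an expected range from 9000 nM to 55000 nM.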

Compound 3, half-maximal inhibitory concentration: 83800 nM
Compound 3: middle estimate off by 3.8-fold (0.58 log units), on the low side; the measured number lies above the stated range.
By their numbers in this assay, from the lowest: compound 2; then compound 1; then compound 3.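

In this assay, the place held by methyl in compound 1 proves not to be neutral, since chloro in place of methyl on this aromatic carbon, para to a large group, gives a 3.5-fold higher number from compound 1 to compound 3 (0.54 log units; beyond the scatter), a step beyond the usual scatter. Among the compounds shown here, this is the first measured change at this position, and it shows that replacing one heavy atom by another here, with no change in ring, hydrogen-bond donors or acceptors, or net charge, weakens the compound; it also runs in the opposite direction to a 2.6-fold lower number from compound 1 to compound 2 (0.41 log units; beyond the scatter), the only other step, which concerns a different place in the molecule. No measurement at hand explains why 4-chlorophenyl stands worse than 4-methylphenyl in this series.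

The compounds shown leave open how a fluoro, a methoxy or an amine on this aromatic carbon would stand against methyl and chloro, since only these two groups are seen here. They also leave open whether the same exchange would move the number in the same direction on compound 2, which carries a five-membered aromatic ring on its carbonyl carbon.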